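Moving the pyridine nitrogen on an indane-imidazole scaffold

The source may report more compounds than this note shows. Statements on the series, on what has been measured and on what is new or still open speak of the compounds shown alone.

Compound 1 `c1ccc(-c2cccc3c2CCC3c2ncc[nH]2)nc1`: > 10000 nM
Compound 2 `c1cc(-c2ccn[nH]2)c2c(c1)C(c1ncc[nH]1)CC2`: 600 nM
Compound 3 `c1ccc2c(c1)CCC2c1ncc[nH]1`: > 10000 nM

In a functional assay on CHO cells for agonist activity at Alpha-1B adrenergic receptor (Homo sapiens), read by FLIPR and calcium flux (a higher number here means that more compound is needed for the effect, a lower number that less compound is needed), compound 1 gives only a limit, > 10000 nM. Compound 2, the best-defined of the three, gives 600 nM in this assay. Compound 3 likewise gives only a limit, > 10000 nM. On these data alone, two of the three values shown thus sit at the same limit (the limit of > 10000 nM in this assay, at which 2 of the 3 values shown sit), so compound 1 stands at the weak end of what is measured here and its true value is unknown.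

Compound 4 `c1cncc(-c2cccc3c2CCC3c2ncc[nH]2)c1` carries pyridin-3-yl in place of pyridin-2-yl on an aromatic carbon. The measured steps that bear on the same place are an at least 16-fold lower number from compound 1 to compound 2 (1.22 log units; beyond the scatter) and an at least 16-fold higher number from compound 2 to compound 3 (1.22 log units; beyond the scatter), while a step that the two limits leave unreadable from compound 1 to compound 3. Both steps at this position that could be read were large, but both involved 1H-pyrazol-5-yl; neither shows what a pyridine with its nitrogen shifted does.

With the same atoms merely joined differently, compound 4 is expected to stay near compound 1, giving an estimated 10000 nM with a range of 2000 nM to 40000 nM, that is an expected a number no higher from compound 1 to compound 4 (the limit leaves the size open), most likely again only a limit.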

Compound 4, half-maximal effective concentration: > 10000 nM
Compound 4 gave a limit, no number (the forecaster's own chance of this, stated with the estimate: 60%); the middle value lies on the limit itself.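

In this assay, pyridin-3-yl, like pyridin-2-yl, does not match 1H-pyrazol-5-yl at this position, with an at least 16-fold higher number from compound 2 to compound 4 (1.22 log units; beyond the scatter). The steps to compound 4 from compound 1 and from compound 3 join two limits and cannot be read, so neither pyridine can be ranked against the other or against hydrogen. Of the groups shown on this aromatic carbon, only 1H-pyrazol-5-yl gives a measured number, and the others all stand at one limit: the limit of > 10000 nM in this assay, at which 3 of the 4 values shown sit.

The compounds shown leave open whether a triazolyl or thiazolyl group, pyridin-4-yl or a simple amine on this carbon would also give a number. They also leave open how far compound 1, compound 3 and compound 4 lie from one another beyond that limit.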